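An Isopropyl Group Replaces 3-Fluorobenzyl on the Aromatic Nitrogen

A few compounds are considered here, and "the series" means these few. Any claim that something is new, unique, unknown or untested is made for them only; others in the source may bear on it.

Three measured compounds share one core and differ only in the group carried on the aromatic nitrogen. Compound 1 `CCOC(=O)c1ccc(-c2nn(C)c3ccccc23)cc1` carries a methyl there. In a functional assay on cells (Platelet, Homo sapiens) for inhibition (a higher number here means a weaker inhibitor, a lower number a stronger inhibitor), compound 1 gives > 10000 nM, which is a limit of the assay rather than a number. Compound 2 `CCOC(=O)c1ccc(-c2nn(Cc3cccc(F)c3)c3ccccc23)cc1` carries a 3-fluorobenzyl. In this assay compound 2 likewise reaches only the limit > 10000 nM. Compound 3 `CCOC(=O)c1ccc(-c2nn(-c3ccoc3)c3ccccc23)cc1` carries a furan-3-yl. In this assay compound 3 also sits at the limit > 10000 nM. The steps between them, a step that the two limits leave unreadable from compound 1 to compound 2, a step that the two limits leave unreadable from compound 1 to compound 3 and a step that the two limits leave unreadable from compound 2 to compound 3, cannot be sized; all that the numbers give is the limit of > 10000 nM in this assay, at which 3 of the 3 values shown sit.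

Compound 4 `CCOC(=O)c1ccc(-c2nn(C(C)C)c3ccccc23)cc1` is the next member of the series. The change from compound 2 is isopropyl in place of 3-fluorobenzyl on an aromatic nitrogen. Among the measured compounds shown here, no measured step bears on this change with a readable size, as every value so far is a limit. The data support only the expectation that compound 4 would again be reported at the limit, which is expected to leave the step of a number no higher from compound 2 to compound 4 (the limit leaves the size open) unreadable as well. In this assay compound 4 is therefore estimated at 10000 nM, with a range from 3000 nM to 30000 nM.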

Compound 4, half-maximal inhibitory concentration: > 10000 nM
Compound 4: only a limit was reported; the forecaster's own chance of this, stated with the estimate: 80%; the middle value lies on the limit itself.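

In this assay compound 4 gives > 10000 nM, which is a limit of the assay and not a number, so no step between compound 4 and compound 1, compound 2 or compound 3 can be read: the limit of > 10000 nM in this assay, at which 4 of the 4 values shown sit.

The compounds shown leave open how strongly any of them inhibits and whether the group on the aromatic nitrogen changes the result in this assay at all.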